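The compounds below may be only part of what the source reports. "The series", "measured", "known", "first", "only" and "open" are said of these compounds alone.

In an ADME assay (liver) for metabolic stability, with Liver microsome (Homo sapiens) as the target, read by LC-MS, using microsomes, tested at 1 uM (on this read-out higher numbers stand for a longer-lived compound and lower numbers for a shorter-lived compound), compound 1 `CN(C)CCCN/C(=N\c1ccnc2cc(Cl)ccc12)c1ccc(Cl)cc1` gives 0.8 h. Compound 3 `CC(C)/C(=N/c1ccnc2cc(Cl)ccc12)NCCCCN1CCCCC1` gives 0.483 h, and these two values lie within the scatter of each other. Compound 2 `C/C(=N/c1ccnc2cc(Cl)ccc12)NCCCCN1CCCCC1` reads > 1 h, which is a limit of the assay and not a number. Among the measured compounds shown here, the only measured step is an at least 2.0-fold lower number from compound 2 to compound 3 (0.31 log units; beyond the scatter), for isopropyl in place of methyl on a carbon with a double bond to nitrogen. That step lies at a different place and bears only loosely on the next change. Compound 4 `CN(C)CCCN/C(=N\c1ccnc2cc(Cl)ccc12)c1ccccc1` differs from compound 1 by hydrogen in place of chloro on an aromatic carbon. For the measured compounds named here, no step at that place has been measured, so no shift beyond the scatter is expected in this assay, and the expected step is a 1.1-fold lower number from compound 1 to compound 4 (0.06 log units; within the scatter). For compound 4 the estimate is 0.7 h, with an expected range of 0.35 h to 1.4 h.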

Compound 4, half-life: > 1 h
Compound 4 was reported as a limit; the forecaster's own chance of this, stated with the estimate: 15%; middle value at least 1.4-fold (0.15 log units) away from the limit.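

In this assay, the first change read at this place, 4-chlorophenyl to phenyl, gives an at least 1.2-fold higher number from compound 1 to compound 4 (0.09 log units; that floor lies within the scatter), so losing the chloro brings no shorter half-life. Compound 4 reads > 1 h, which is a limit of the assay and not a number. The true size of the step stays unknown because of that limit: the limit of > 1 h in this assay, at which 2 of the 4 values shown sit.

Going by these compounds, whether fluoro or methoxy at this place would read differently remains open. Also open, on these data alone, is whether the same change would give a similar result with a longer chain in place of the side chain of compound 1.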